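Methoxy to Fluoro on the Urea Aryl Ring

The source may report more compounds than this note shows. Statements on the series, on what has been measured and on what is new or still open speak of the compounds shown alone.

Three compounds have been measured in a functional assay on CRL2813 cells (Homo sapiens) for cytotoxicity, read by sulforhodamine B assay, with a stated time of 5 days; on this read-out lower numbers stand for stronger inhibition and higher numbers for weaker inhibition:
compound 1 `O=C(Nc1cccc(C(F)(F)F)c1)N[C@H]1CC[C@H](Oc2ccccc2F)CC1` — 2450 nM
compound 2 `COc1ccc(NC(=O)N[C@H]2CC[C@H](Oc3ccc(F)cc3)CC2)cc1` — > 20000 nM
compound 3 `O=C(Nc1cccc(C(F)(F)F)c1)N[C@H]1CC[C@H](Oc2ccccc2C(F)(F)F)CC1` — 1400 nM

Compound 2 stands at a limit of this assay rather than at a number, (the limit of > 20000 nM in this assay, at which 1 of the 3 values shown sits). Compound 4 `O=C(Nc1ccc(F)cc1)N[C@H]1CC[C@H](Oc2ccc(F)cc2)CC1` differs from compound 2 by fluoro in place of methoxy on an aromatic carbon. Among the compounds with values here, the only measured step, a 1.8-fold lower number from compound 1 to compound 3 (0.24 log units; within the scatter), sits on the other aromatic ring and does not bear on this change. Compound 1 and compound 3, both carrying trifluoromethyl on the urea aryl ring, give numbers within the assay. Compound 4 is therefore estimated at 12000 nM, with a range from 3000 nM to 40000 nM, which is the expected step of an at least 1.6-fold lower number from compound 2 to compound 4 (0.22 log units; that floor lies within the scatter).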

Compound 4, half-maximal inhibitory concentration: 20000 nM
Beside the measured number, compound 4's estimate is 1.7-fold (0.22 log units) below it; measured number inside the range.
By their numbers in this assay, from the lowest: compounds 3 and 1 (each within the scatter of the next); then compound 4.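

In this assay compound 4 gives 20000 nM and thus shows that, with fluoro on this aromatic carbon para to a large group, the read-out returns a number rather than a limit. The change from 4-methoxyphenyl to 4-fluorophenyl gives a number no higher from compound 2 to compound 4 (the limit leaves the size open), and the size of this step cannot be read. Compound 2 stands at a limit, not a number: the limit of > 20000 nM in this assay, at which 1 of the 4 values shown sits. From the compounds shown here alone, whether compound 2 lies close to compound 4 or far from it stays open. So does how an amine or a carboxylic acid would read on this aromatic carbon.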